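From chloro to ethoxycarbonyl on a shared core

The compounds below may be only part of what the source reports. "The series", "measured", "known", "first", "only" and "open" are said of these compounds alone.

Measured in a functional assay on B16-F0 cells (Mus musculus) for inhibition, read by CCK-8 assay, with a stated time of 48 h; on this read-out lower numbers stand for stronger inhibition and higher numbers for weaker inhibition:
Compound 1 `COc1cc(-c2ccnc3cc(-c4ccc(Cl)cc4)nn23)cc(OC)c1OC`: 4090 nM
Compound 2 `COc1cc(-c2ccnc3cc(-c4ccc(C)c(C)c4)nn23)cc(OC)c1OC`: 391 nM
Compound 3 `COc1cc(-c2ccnc3cc(-c4cn(C)c5ccccc45)nn23)cc(OC)c1OC`: 185 nM

Compound 1 gives the highest number of the three and is the weakest of this set. Both measured steps away from it were large: a 10-fold lower number from compound 1 to compound 2 (1.02 log units; beyond the scatter), and a 22-fold lower number from compound 1 to compound 3 (1.34 log units; beyond the scatter). The remaining step was modest: a 2.1-fold lower number from compound 2 to compound 3 (0.33 log units; beyond the scatter).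

Compound 4 `CCOC(=O)c1ccc(-c2cc3nccc(-c4cc(OC)c(OC)c(OC)c4)n3n2)cc1` keeps the core of compound 1 and changes one group: ethoxycarbonyl in place of chloro on an aromatic carbon. Within the data shown here, no measured step makes this exact change. The two steps from compound 1 replace the whole 4-chlorophenyl group, so they bear on it only indirectly. They show that changes at this place can move the number a long way, yet neither involves ethoxycarbonyl. With compound 1 at the top of the set at 4090 nM, a modest step toward a lower number is expected in this assay, though with little certainty. The estimated step is a 2.3-fold lower number from compound 1 to compound 4 (0.36 log units; beyond the scatter). For compound 4 the estimated value is 1800 nM, with an expected range from 500 nM to 6000 nM.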

Compound 4, half-maximal inhibitory concentration: > 10000 nM
Compound 4 was reported as a limit; the forecaster's own chance of this, stated with the estimate: 10%; middle value at least 5.5-fold (0.74 log units) from the limit.
By their numbers in this assay, from the lowest: compound 3; then compound 2; then compound 1. At a limit, above all of these: compound 4.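

Ethoxycarbonyl in place of chloro on the aromatic carbon para to a large group gives an at least 2.4-fold higher number from compound 1 to compound 4 (0.38 log units; beyond the scatter). Among these compounds, this is the first step in the set that raises the number, so the position does not only tolerate change toward lower numbers; a swap of this one group, with the rest of the 4-chlorophenyl ring kept, can also move it upward. The result for compound 4 in this assay is a limit, not a number: the limit of > 10000 nM in this assay, at which 1 of the 4 values shown sits.

The compounds shown do not separate the larger heavy-atom count of ethoxycarbonyl from its carbonyl and hydrogen-bond acceptors as the feature behind this step. From the compounds shown here alone, it remains open whether a carboxylic acid, a primary amide or a methoxy group at the same carbon would stay at this limit or give a lower number.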